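Aryl amine swap in a cytotoxicity series at the limit

A few compounds are considered here, and "the series" means these few. Any claim that something is new, unique, unknown or untested is made for them only; others in the source may bear on it.

Measured compounds:
Compound 1 `O=C(/C=C\Nc1cnc2ccccc2c1)c1nc(-c2ccc(C(F)(F)F)cc2)n2ccccc12`: in a functional assay on MDA-MB-231 cells (Homo sapiens) for cytotoxicity, read by MTT assay, with a stated time of 48 h (on this read-out higher numbers stand for weaker inhibition and lower numbers for stronger inhibition), compound 1 gives > 30000 nM, which is a limit of the assay and not a number.
Compound 2 `Cc1cc2cc(N/C=C\C(=O)c3nc(-c4ccc(F)cc4)n4ccccc34)ccc2[nH]1`: in this assay compound 2 gives > 30000 nM, a limit of the assay.
Compound 3 `O=C(/C=C\Nc1ccc2cc[nH]c2c1)c1nc(-c2ccc(C(F)(F)F)cc2)n2ccccc12`: in this assay compound 3 gives > 30000 nM, again a limit.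

Within the data shown here, compound 2 therefore stands at the limit, and so does every other compound measured so far; all three values sit at the limit of > 30000 nM in this assay, at which 3 of the 3 values shown sit. Among the measured compounds shown here, the one single-point step available, a step that the two limits leave unreadable from compound 1 to compound 3, runs from one limit to another and its size cannot be read.

Compound 4 `O=C(/C=C\Nc1ccc(Cl)cc1)c1nc(-c2ccc(F)cc2)n2ccccc12` differs from compound 2 in one place: 4-chlorophenyl in place of 2-methyl-1H-indol-5-yl on an amine nitrogen. For the measured compounds named here, no measured step bears on this particular change, and the only measured step is unreadable, so there is no evidence for a move in either direction. Since every compound in the series sits at the limit, compound 4 is expected to sit there too, with a high chance that the assay again reports only a limit. The estimate for compound 4 in this assay is 40000 nM, in a range from 15000 nM to 150000 nM. The step that the limit leaves unreadable from compound 2 to compound 4 is thus expected to lie within the scatter, with the true size unreadable if both values remain limits.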

Compound 4, half-maximal inhibitory concentration: 4250 nM
Estimate against measurement, compound 4: 9.4-fold (0.97 log units) above; measured number below the stated range.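

In this assay, the group on the amine nitrogen can take the read-out off the limit: 4-chlorophenyl in place of 2-methyl-1H-indol-5-yl gives an at least 7.0-fold lower number from compound 2 to compound 4 (0.84 log units; beyond the scatter). Compound 2 gives > 30000 nM, which is a limit of the assay, so this step sets only a lower bound on the size of the change. A readable number remains the exception among the compounds shown, with compound 4 the only one to give one: the limit of > 30000 nM in this assay, at which 3 of the 4 values shown sit.

The compounds shown do not tell whether the change in compound 4 follows from the chlorine, from the 4-chlorophenyl ring as a whole, or from the loss of 2-methyl-1H-indol-5-yl, and the step from compound 1 to compound 3 cannot be read, as it runs between two limits. A plain phenyl, a 4-methoxyphenyl or a 4-aminophenyl group on the amine nitrogen would separate these readings, and 4-chlorophenyl paired with the 4-(trifluoromethyl)phenyl group of compound 1 would test whether the number carries over to that version of the core.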